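Aryl swap on a dihydrofolate reductase inhibitor

This account rests on a few compounds, and the source may have more. Where it says the series, first, only, none or still open, it means among the compounds named here.

compound 1 `COc1ccc(OCCCON2C(N)=NC(N)=NC23CCOCC3)cc1` — > 90%
compound 2 `NC1=NC2(CCOCC2)N(OCCCOc2cc(Cl)c(Cl)cc2Cl)C(N)=N1` — > 90%

In an assay on isolated protein for inhibition of Dihydrofolate reductase (Homo sapiens), read by spectrophotometry, using NADPH, with stated times of 5 s and 6 min, tested at 5 uM (a lower number here means a weaker effect, a higher number a stronger effect of the compound at the concentration tested), compound 1 gives > 90%, which is a limit of the assay. In this assay compound 2 gives > 90%, likewise a limit of the assay. The step that the two limits leave unreadable from compound 1 to compound 2 therefore cannot be read, because of the limit of > 90% in this assay, at which 2 of the 2 values shown sit. Compound 2 thus stands at the limit, with nothing measurable separating it from compound 1. Compound 3 `NC1=NC2(CCOCC2)N(OCCCOc2ccccc2Br)C(N)=N1` differs from compound 2 in one place: 2-bromophenyl in place of 2,4,5-trichlorophenyl on an oxygen on a saturated carbon. Going by the values given here, no measured step has a readable size, so none bears on this change. Compound 3 is expected to show a number no higher from compound 2 to compound 3 (the limit leaves the size open), no step beyond the scatter. For compound 3 the inhibition is estimated at 90%, from 70% to 100%.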

Compound 3, a percentage reported as inhibition, at one concentration (the size of the read-out at that concentration, not a potency): 83.8%
The estimate for compound 3 lay 6.2 percentage points above the measured number, within the range that was stated.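

Going by these compounds alone, compound 3 is the first compound here at this place, on an oxygen on a saturated carbon, to give a number in this assay rather than a limit: the limit of > 90% in this assay, at which 2 of the 3 values shown sit. With 2-bromophenyl at this place, the result is a number at least 6.2 percentage points lower from compound 2 to compound 3 (that floor lies within the scatter), and a number at least 6.2 percentage points lower from compound 1 to compound 3 (that floor lies within the scatter). The change of aryl group therefore has a lower bound on its size, but neither bound shows a step beyond the scatter.

On these data alone, the true size of both steps remains open. So does the effect of replacing the aryl group with a carboxylic acid or an amine.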